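Working notes: chloro in place of carboxy

The source may report more compounds than this note shows. Statements on the series, on what has been measured and on what is new or still open speak of the compounds shown alone.

In an ADME assay on WI-38 cells (Homo sapiens) for cytotoxicity, read by sulforhodamine B assay, with a stated time of 24 h (a higher number here means a weaker inhibitor, a lower number a stronger inhibitor), compound 1 `O=C1Nc2ccc(S(=O)(=O)N3CCOCC3)cc2/C1=N/c1ccc(Br)cc1` gives 372000 nM, compound 2 `Cc1ccc(/N=C2\C(=O)Nc3ccc(S(=O)(=O)N4CCOCC4)cc32)cc1` gives 309000 nM and compound 3 `O=C1Nc2ccc(S(=O)(=O)N3CCOCC3)cc2/C1=N/c1ccc(C(=O)O)cc1` gives 313000 nM. Compound 3 thus stands within the scatter of both other compounds, and the three numbers form a single level.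

Compound 4 `O=C1Nc2ccc(S(=O)(=O)N3CCOCC3)cc2/C1=N/c1ccc(Cl)cc1` has chloro in place of carboxy on an aromatic carbon, para to a large group: chloro in place of carboxy on an aromatic carbon. Chloro itself has no measured neighbour yet, so the bearing comes from the other swaps at this same place. Carboxy for bromo gave a 1.2-fold lower number from compound 1 to compound 3 (0.07 log units; within the scatter), and carboxy for methyl gave a 1.0-fold higher number from compound 2 to compound 3 (0.01 log units; within the scatter). Methyl for bromo gave a 1.2-fold lower number from compound 1 to compound 2 (0.08 log units; within the scatter). None of these steps leaves the scatter, so no step beyond the scatter, in either direction, is expected in this assay. The expected step is a 1.1-fold higher number from compound 3 to compound 4 (0.04 log units; within the scatter). Compound 4 is estimated at 340000 nM, with an expected range of 210000 nM to 540000 nM.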

Compound 4, half-maximal inhibitory concentration: 468000 nM
Compound 4: middle estimate off by 1.4-fold (0.14 log units), on the low side; low and high end bracket the measured number.
By their numbers in this assay, from the lowest: compounds 2, 3, 1 and 4 (each within the scatter of the next).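

In this assay, chloro adds a fourth group at this place, para to a large group, and every step to it stays within the scatter: a 1.5-fold higher number from compound 3 to compound 4 (0.17 log units; within the scatter), a 1.5-fold higher number from compound 2 to compound 4 (0.18 log units; within the scatter) and a 1.3-fold higher number from compound 1 to compound 4 (0.10 log units; within the scatter). Even the exchange of carboxy, with its hydrogen-bond donor and acceptor, for chloro, which has neither, does not leave the scatter, so the four compounds still form a single level. No measurement offered here accounts for this result.

From the compounds shown here alone, whether an amine or a longer chain at this place would stay on that level remains open. Going by these compounds, the effect of a change elsewhere on the shared core also remains open, since these compounds differ only at this one place.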